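Nitrile for Nitro on a Thiourea Series in Melanoma Cells

The compounds below may be only part of what the source reports. "The series", "measured", "known", "first", "only" and "open" are said of these compounds alone.

Three thioureas built on a shared core were tested in a functional assay on B16-F10 cells (Mus musculus) for inhibition, read by MTT assay, with a stated time of 72 h; on this read-out lower numbers stand for stronger inhibition and higher numbers for weaker inhibition. Compound 1 `CC1(C)CC(NC(=S)Nc2ccc(C#N)cc2)c2cc(F)ccc2O1` gives 5000 nM. Compound 2 `CC1(C)CC(NC(=S)Nc2ccc([N+](=O)[O-])cc2)c2cc(F)ccc2O1` gives 4000 nM. Compound 3 `CC1(C)CC(NC(=S)Nc2cccc([N+](=O)[O-])c2)c2cc(Cl)ccc2O1` has a core that differs from that of compound 2 in a way not broken down here. Compound 3 gives 6000 nM. All three numbers lie within the usual scatter of one another, so none of the three is told apart from the others by this read-out.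

Compounds 2 and 1 differ in one place: cyano in place of nitro on an aromatic carbon. That change gave a 1.3-fold higher number from compound 2 to compound 1 (0.10 log units; within the scatter), a step that stays within the scatter.

Compound 4 `CC1(C)CC(NC(=S)Nc2cccc(C#N)c2)c2cc(Cl)ccc2O1` is not yet measured. It differs from compound 3 by cyano in place of nitro on an aromatic carbon. For the measured compounds named here, this is the same kind of change as the one from compound 2 to compound 1, but the place is not the same: in compound 1 the cyano sits para to a large group, in compound 4 it sits meta to a large group, and the core of compound 3 carries chloro where compounds 1 and 2 carry fluoro.

Resting on the step from compound 2 to compound 1, compound 4 is expected to show a 1.2-fold higher number from compound 3 to compound 4 (0.07 log units; within the scatter) in this assay, a step of about the same size as a 1.3-fold higher number from compound 2 to compound 1 (0.10 log units; within the scatter). Compound 4 is therefore estimated at 7000 nM, with a likely range from 3500 nM to 14000 nM.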

Compound 4, half-maximal inhibitory concentration: 6000 nM
The estimate for compound 4 lay 1.2-fold (0.07 log units) above the measured number; the range from low to high includes it.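

Putting cyano in place of nitro on an aromatic carbon gave no change at the digits printed from compound 3 to compound 4 (within the scatter) in this assay. Set beside the earlier step, the same change reads alike on the two cores, with no difference between the two steps that stands clear of the scatter: the same change on two cores in this assay, a 1.3-fold higher number (0.10 log units; within the scatter) from compound 2 to compound 1 and no change at the digits printed (within the scatter) from compound 3 to compound 4, 1.3-fold (0.10 log units) apart, within the scatter of two such steps. This shows that, across these two pairs, nitro and cyano could be exchanged without a detectable shift in the read-out, but it does not show that the change carries over unaltered in any finer sense, since steps this small would hide a modest difference, and two pairs cannot establish a rule for the series.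

The compounds shown leave open how the place of the group and the halogen on the core each count on their own, since the two pairs differ in both at once, with cyano meta to a large group and chloro on the core in compound 4, and fluoro on the core of compound 1 with its cyano placed differently. They also leave open whether a group of another kind at that aromatic carbon, such as an amine, a carboxylic acid or a methoxy group, would move the number in this assay beyond the scatter.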